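The source may report more compounds than this note shows. Statements on the series, on what has been measured and on what is new or still open speak of the compounds shown alone.

Three compounds share one core and differ at a single aromatic carbon. Compound 1 `Cc1cc(Cl)c(S(C)(=O)=O)cc1C(=O)N=C(N)N` gives 25 nM in a functional assay for inhibition of sodium/hydrogen exchanger (Oryctolagus cuniculus); on this read-out lower numbers stand for stronger inhibition and higher numbers for weaker inhibition. Compound 2 `CCCCCc1cc(C)c(C(=O)N=C(N)N)cc1S(C)(=O)=O` gives 27 nM in this assay, and compound 3 `Cc1cc(-c2ccc(Cl)cc2)c(S(C)(=O)=O)cc1C(=O)N=C(N)N` gives 45 nM, the highest of the three numbers, though the steps of a 1.8-fold higher number from compound 1 to compound 3 (0.26 log units; within the scatter) and a 1.7-fold higher number from compound 2 to compound 3 (0.22 log units; within the scatter) both stay within the scatter. Compound 4 `Cc1cc(-c2ccc(Cl)cc2Cl)c(S(C)(=O)=O)cc1C(=O)N=C(N)N` carries chloro in place of hydrogen on an aromatic carbon, so the 4-chlorophenyl becomes 2,4-dichlorophenyl. Among the measured compounds shown here, no measured step adds a chloro to an attached phenyl ring; the three measured swaps at this position all stayed within the scatter. The expected step of a 1.1-fold higher number from compound 3 to compound 4 (0.05 log units; within the scatter) is therefore none beyond the scatter. Compound 4 is estimated at 50 nM, with a range from 20 nM to 130 nM.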

Compound 4, half-maximal inhibitory concentration: 42 nM
Compound 4: middle estimate off by 1.2-fold (0.08 log units), on the high side, within the range that was stated.
By their numbers in this assay, from the lowest: compounds 1, 2, 4 and 3 (each within the scatter of the next).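

Turning 4-chlorophenyl into 2,4-dichlorophenyl (a 1.1-fold lower number from compound 3 to compound 4 (0.03 log units; within the scatter)) in this assay shows that a change within the attached phenyl ring, and not only a swap of the whole group, leaves the number within the scatter. The larger comparisons (a 1.6-fold higher number from compound 2 to compound 4 (0.19 log units; within the scatter)) and (a 1.7-fold higher number from compound 1 to compound 4 (0.23 log units; within the scatter)) stay within the scatter too, so chloro, pentyl and both substituted phenyl groups cannot be told apart at this carbon. Nothing available explains this flat response. From the compounds shown here alone, whether an amine or a carboxylic acid at this carbon would also stay within the scatter remains open.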